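Para-substituent swaps in the diaryl urea series: compound 4

A few compounds are considered here, and "the series" means these few. Any claim that something is new, unique, unknown or untested is made for them only; others in the source may bear on it.

Three ureas sharing one core have been measured in a functional assay on A2780 cells (Homo sapiens) for inhibition, with a stated time of 72 h; on this read-out higher numbers stand for weaker inhibition and lower numbers for stronger inhibition. Compound 1 `CN1c2ccc(NC(=O)Nc3ccc([N+](=O)[O-])cc3)cc2C(C)(C)C(=O)C1(C)C` gives 3800 nM. Compound 2 `CN1c2ccc(NC(=O)Nc3ccc(C(F)(F)F)cc3)cc2C(C)(C)C(=O)C1(C)C` gives 2580 nM. Compound 3 `CN1c2ccc(NC(=O)Nc3ccc(OC(F)(F)F)cc3)cc2C(C)(C)C(=O)C1(C)C` gives 2400 nM. Compound 3 has the lowest number of the three, but its separation from the others is small: a 1.1-fold lower number from compound 2 to compound 3 (0.03 log units; within the scatter) and a 1.6-fold lower number from compound 1 to compound 3 (0.20 log units; within the scatter), and likewise a 1.5-fold lower number from compound 1 to compound 2 (0.17 log units; within the scatter). None of the three changes on the aromatic carbon moves this assay beyond its scatter.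

Compound 4 `CN1c2ccc(NC(=O)Nc3ccc(N)cc3)cc2C(C)(C)C(=O)C1(C)C` differs from compound 3 in a single place: amino in place of trifluoromethoxy on an aromatic carbon. Among the compounds with values here, no measured step involves the amino group, so the three recorded exchanges on that same aromatic carbon are the only guide, and each of them stayed within the scatter. The expectation is therefore no step beyond the scatter, with the estimate placed a little toward the centre of the three measured numbers rather than at the lowest of them.

Compound 4 is expected to give 3500 nM in this assay, within 1200 nM to 10000 nM. Within the data shown here, the estimated step is a 1.5-fold higher number from compound 3 to compound 4 (0.16 log units; within the scatter), and a result anywhere within the scatter of compound 3 would be consistent with the series so far.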

Compound 4, half-maximal inhibitory concentration: 7700 nM
Compound 4: the middle estimate sits 2.2-fold (0.34 log units) below what was measured; the range from low to high includes it.
By their numbers in this assay, from the lowest: compounds 3, 2 and 1 (each within the scatter of the next); then compound 4.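

In this assay the aromatic carbon para to a large group had so far shown no step beyond the scatter, and the nitro, trifluoromethyl and trifluoromethoxy compounds remain within the scatter of one another. Amino on this carbon separates compound 4 from all three, with a 3.2-fold higher number from compound 3 to compound 4 (0.51 log units; beyond the scatter) and a 3.0-fold higher number from compound 2 to compound 4 (0.47 log units; beyond the scatter) and a 2.0-fold higher number from compound 1 to compound 4 (0.31 log units; beyond the scatter) and with all three steps modest and in the same direction, so this position is not indifferent to every exchange and compound 4 is the weakest of the four on this read-out. Compared with compound 3, trifluoromethoxy with 5 heavy atoms and 0 hydrogen-bond donors leaves and amino with 1 heavy atom and 1 hydrogen-bond donor enters, but no measurement at hand ties the higher number to either difference.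

Going by these compounds, whether the step belongs to amino alone or extends to related groups on this carbon, such as a methylamino group, a dimethylamino group, an acetamide or a hydroxyl, remains open. Also open, on these data alone, is whether a carboxylic acid at this place would follow amino or stay with the other three groups.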